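Turning a chain end into a ring

A few compounds are considered here, and "the series" means these few. Any claim that something is new, unique, unknown or untested is made for them only; others in the source may bear on it.

compound 1 `CCCCCCCCCS(=O)(=O)/C=C/c1ccc(O)c(O)c1`: 7700 nM
compound 2 `CCCCCCCCS(=O)(=O)/C=C/c1ccc(O)c(O)c1`: 6400 nM

Within the data shown here, in a functional assay, read by fluorescence and spectrophotometry, with a stated time of 1 h (on this read-out lower numbers stand for an effect already at smaller amounts and higher numbers for an effect only at larger amounts of compound), compound 2 gives 6400 nM and stands level, within the scatter, with the only other measured compound. The change to compound 3 `O=S(=O)(/C=C/c1ccc(O)c(O)c1)CCCC1CCCC1` is cyclopentyl in place of pentyl on a saturated chain carbon, three bonds along the chain from a sulfonyl sulfur and puts cyclopentyl in place of pentyl. Among the measured compounds shown here, the only measured step of a 1.2-fold lower number from compound 1 to compound 2 (0.08 log units; within the scatter) puts hydrogen in place of methyl and involves no ring, so it offers weak guidance. No step beyond the scatter is expected in this assay for this change. The estimated step of a 1.1-fold lower number from compound 2 to compound 3 (0.03 log units; within the scatter) remains uncertain. Compound 3 is expected at 6000 nM within an estimated range of 2500 nM to 14000 nM.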

Compound 3, half-maximal effective concentration: 6300 nM
Estimate against measurement, compound 3: 1.1-fold (0.02 log units) below; the measured number falls inside the stated range.
By their numbers in this assay, from the lowest: compounds 3, 2 and 1 (each within the scatter of the next).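

In this assay, joining the chain end into a ring, with cyclopentyl in place of pentyl, leaves the number within the scatter (a 1.0-fold lower number from compound 2 to compound 3 (0.01 log units; within the scatter)). The same holds for cyclopentyl in place of hexyl (a 1.2-fold lower number from compound 1 to compound 3 (0.09 log units; within the scatter)). At this place, three bonds along the chain from a sulfonyl sulfur, the ring and the open chains therefore cannot be told apart in this assay, and nothing available explains this result. Still open, on these data alone, is whether a cyclohexyl or phenyl ring, or an amine or carboxylic acid on the chain, would shift the number beyond the scatter.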